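Oxime-linked arylpiperazines: a methoxy substituent on the aryl ring

This account rests on a few compounds, and the source may have more. Where it says the series, first, only, none or still open, it means among the compounds named here.

Measured so far:
compound 1 `Cc1ccccc1/C(CCN1CCN(c2ccccn2)CC1)=N/O`, 4.2 nM
compound 2 `O/N=C(/CCN1CCN(c2ncccn2)CC1)c1ccccc1`, 69 nM
compound 3 `CCO/N=C(\CCN1CCN(c2ccccc2)CC1)c1ccccc1`, 109 nM

The series shares an oxime ether or oxime tethered through a short chain to a piperazine bearing an aromatic substituent, tested in a functional assay on HEK293 cells with D(4) dopamine receptor (Homo sapiens) as the target, read by FLIPR; a higher number here means that more compound is needed for the effect, a lower number that less compound is needed. Compound 3 gives the highest of the three numbers. Its gap to compound 2 lies within the scatter of the method, so the two are not separated; its gap to compound 1 lies beyond the scatter, and compound 1 gives the lowest number of the three.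

Compound 4 `CCO/N=C(\CCN1CCN(c2ccc(OC)cc2)CC1)c1ccccc1` differs from compound 3 in one place: methoxy in place of hydrogen on an aromatic carbon. Read one bond further out, the difference is phenyl to 4-methoxyphenyl. Within the data shown here, no pair already measured isolates this change, so the size and direction of the step rest on judgment rather than on a measured precedent. The expectation is a step of modest size in this assay, not clearly beyond the scatter in either direction, a 1.4-fold lower number from compound 3 to compound 4 (0.13 log units; within the scatter). On that basis compound 4 is estimated at 80 nM, within a range from 25 nM to 300 nM.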

Compound 4, half-maximal effective concentration: > 10000 nM
Compound 4: a limit, no number; the forecaster's own chance of this, stated with the estimate: 5%; at least 120-fold (2.09 log units) between middle value and limit.
By their numbers in this assay, from the lowest: compound 1; then compounds 2 and 3 (each within the scatter of the next). At a limit, above all of these: compound 4.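

In this assay compound 4 gives > 10000 nM as a limit of the assay and not a number. Among these compounds, the change of hydrogen to methoxy, on an aromatic carbon para to a large group, gives an at least 91-fold higher number from compound 3 to compound 4 (1.96 log units; beyond the scatter) and is the first single-place comparison, so this place on the ring proves not to be indifferent to substitution, even though the entering group holds only 2 heavy atoms. The step is a lower bound rather than a size, and the reading is the only one of its kind in the series: the limit of > 10000 nM in this assay, at which 1 of the 4 values shown sits.

The compounds shown leave open whether the rise belongs to methoxy itself or to any group at this place, a question that fluorine, hydroxyl or methyl on the same carbon would separate. They also leave open whether the same change carries over to the free oximes, compound 1 and compound 2, whose piperazine substituents are not the phenyl ring of compound 3 and whose oxime lacks the ethyl group.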